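Halogen Swap on the Anilino Ring: Chloro to Bromo

This account rests on a few compounds, and the source may have more. Where it says the series, first, only, none or still open, it means among the compounds named here.

Compound 1 `COc1ccccc1Nc1cc(C)nc(SCc2nc3ccccc3[nH]2)n1` gives > 100000 nM in a functional assay on MCF7 cells (Homo sapiens) for cytotoxicity, read by MTT assay, with a stated time of 72 h (on this read-out lower numbers stand for stronger inhibition and higher numbers for weaker inhibition), a limit of the assay (the limit of > 100000 nM in this assay, at which 1 of the 3 values shown sits).
Compound 2 `Cc1cc(Nc2ccc(F)cc2)nc(SCc2nc3ccccc3[nH]2)n1` gives 42200 nM in this assay.
Compound 3 `Cc1cc(Nc2ccc(Cl)cc2)nc(SCc2nc3ccccc3[nH]2)n1` gives 33600 nM in this assay.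

Compound 3 holds the lowest of the two numbers, yet the step between them is a 1.3-fold lower number from compound 2 to compound 3 (0.10 log units; within the scatter), within the scatter, so the two cannot be ranked. Compound 4 `Cc1cc(Nc2ccc(Br)cc2)nc(SCc2nc3ccccc3[nH]2)n1` is not yet measured; its difference from compound 3 is bromo in place of chloro on an aromatic carbon. Among the measured compounds shown here, the only measured step of the same kind is the exchange of fluoro for chloro between compound 2 and compound 3, which stayed within the scatter. The steps of an at least 2.3-fold lower number from compound 1 to compound 2 (0.37 log units; beyond the scatter) and an at least 2.9-fold lower number from compound 1 to compound 3 (0.47 log units; beyond the scatter) concern another change and bear little here. For compound 4 in this assay a step of a 1.1-fold lower number from compound 3 to compound 4 (0.05 log units; within the scatter) is therefore expected, none beyond the scatter. Compound 4 is estimated at 30000 nM, between 12000 nM and 80000 nM.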

Compound 4, half-maximal inhibitory concentration: 38000 nM
For compound 4 the middle estimate is 1.3-fold (0.10 log units) below the measured one; low and high end bracket the measured number.
By their numbers in this assay, from the lowest: compounds 3, 4 and 2 (each within the scatter of the next). At a limit, above all of these: compound 1.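

With bromo on the aromatic carbon para to a large group, the three halogens cannot be ranked in this assay: a 1.1-fold higher number from compound 3 to compound 4 (0.05 log units; within the scatter) and a 1.1-fold lower number from compound 2 to compound 4 (0.05 log units; within the scatter) both stay within the scatter. Among the compounds shown here, the exchange of 2-methoxyphenyl for 4-bromophenyl gives an at least 2.6-fold lower number from compound 1 to compound 4 (0.42 log units; beyond the scatter), matching the earlier steps from compound 1 to the fluoro and chloro compounds. That step is only a bound, as compound 1 stands at a limit: the limit of > 100000 nM in this assay, at which 1 of the 4 values shown sits.

From the compounds shown here alone, whether an amine, a hydroxyl or a carboxylic acid in place of the halogen would move the number beyond the scatter stays open.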